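The source may report more compounds than this note shows. Statements on the series, on what has been measured and on what is new or still open speak of the compounds shown alone.

Measured in an ADME assay on HEK293 cells (Homo sapiens) for cytotoxicity, with a stated time of 72 h; a lower number here means that less compound is needed, a higher number that more compound is needed for the effect:
- compound 1 `C=C[C@@](C)(/C=C/c1ccc(O)cc1)CCC=O`: > 36600 nM, a limit
- compound 2 `C=C[C@@](C)(/C=C/c1ccc(O)cc1)CCCO`: > 36600 nM, a limit
- compound 3 `C=C[C@@](C)(/C=C/c1ccc(O)cc1)CC/C=C/C(=O)OCC`: > 36600 nM, a limit

Compound 3 has no number, only this limit, and it shares that position with the other two: the limit of > 36600 nM in this assay, at which 3 of the 3 values shown sit.

Compound 4 `C=C[C@@](C)(/C=C/c1ccc(O)cc1)CC/C=C/C(=O)OCc1ccccc1` differs from it as follows: phenyl in place of methyl on a saturated chain carbon bound to an oxygen next to a carbonyl group. This places phenyl in place of methyl on a saturated chain carbon bound to an oxygen next to a carbonyl group.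

Among the measured compounds shown here, three measured steps bear on this change only loosely: a step that the two limits leave unreadable from compound 1 to compound 2, a step that the two limits leave unreadable from compound 1 to compound 3 and a step that the two limits leave unreadable from compound 2 to compound 3. None has a readable size.

The expected step is a step that the limit leaves unreadable from compound 3 to compound 4, with no direction expected beyond the scatter in this assay, because the limit of > 36600 nM in this assay, at which 3 of the 3 values shown sit, offers nothing firmer.

Compound 4 is estimated at 40000 nM, with an expected range of 15000 nM to 80000 nM.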

Compound 4, half-maximal effective concentration: > 36600 nM
Compound 4: only a limit was reported; the forecaster's own chance of this, stated with the estimate: 75%; the middle value is on the limit's open side.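

In this assay, among the compounds shown here, compound 4 gives > 36600 nM, a limit and not a number, so no step from compound 3 to compound 4 can be read. Left open is whether any change shown shifts this read-out, since all the compounds sit at one limit: the limit of > 36600 nM in this assay, at which 4 of the 4 values shown sit.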